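Alkyl for methoxy on the triazole aryl group

This account rests on a few compounds, and the source may have more. Where it says the series, first, only, none or still open, it means among the compounds named here.

Compound 1 `COc1ccc(-n2cc(COc3cccc(NC(=O)Nc4ccc(Cl)c(C(F)(F)F)c4)c3)nn2)cc1`: 4680 nM
Compound 2 `N#Cc1ccccc1-n1cc(COc2cccc(NC(=O)Nc3ccc(Cl)c(C(F)(F)F)c3)c2)nn1`: 1970 nM
Compound 3 `CCc1ccc(-n2cc(COc3cccc(NC(=O)Nc4ccc(Cl)c(C(F)(F)F)c4)c3)nn2)cc1`: 1950 nM

In a functional assay on HepG2 cells (Homo sapiens) for inhibition, read by MTT assay, with a stated time of 72 h (on this read-out lower numbers stand for stronger inhibition and higher numbers for weaker inhibition), compound 1 gives the highest of the three numbers, so it is the weakest inhibitor of the measured set; it sits above compound 2 by a 2.4-fold lower number from compound 1 to compound 2 (0.38 log units; beyond the scatter) and above compound 3 by a 2.4-fold lower number from compound 1 to compound 3 (0.38 log units; beyond the scatter), while the two lower compounds are separated only by a 1.0-fold lower number from compound 2 to compound 3 (0.00 log units; within the scatter).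

Compound 4 `CC(C)c1ccc(-n2cc(COc3cccc(NC(=O)Nc4ccc(Cl)c(C(F)(F)F)c4)c3)nn2)cc1` is the unmeasured member. It differs from compound 1 by isopropyl in place of methoxy on an aromatic carbon.

Among the measured compounds shown here, the step that bears most directly on it is the one to compound 3, where ethyl replaced methoxy on the same aromatic carbon and gave a 2.4-fold lower number from compound 1 to compound 3 (0.38 log units; beyond the scatter). The step to compound 2, a different change on the aromatic nitrogen, gave a 2.4-fold lower number from compound 1 to compound 2 (0.38 log units; beyond the scatter), so every departure from the methoxy-bearing compound 1 so far has lowered the number by a modest, similar amount. Isopropyl is another alkyl group entering at the place where ethyl helped, so a modest drop beyond the scatter is expected, not a large one.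

Compound 4 is therefore estimated at 2000 nM in this assay, within 1000 nM to 4500 nM, a step of a 2.3-fold lower number from compound 1 to compound 4 (0.37 log units; beyond the scatter) that is expected to mirror the ethyl case.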

Compound 4, half-maximal inhibitory concentration: 2470 nM
The estimate for compound 4 lay 1.2-fold (0.09 log units) below the measured number; the measured number falls inside the stated range.
By their numbers in this assay, from the lowest: compounds 3, 2, 4 and 1 (each within the scatter of the next, the first and the last beyond it).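

In this assay, isopropyl on the aromatic carbon para to a large group is not separated from methoxy: a 1.9-fold lower number from compound 1 to compound 4 (0.28 log units; within the scatter) lies within the scatter, whereas the ethyl replacement at the same place, with a 2.4-fold lower number from compound 1 to compound 3 (0.38 log units; beyond the scatter), lay just beyond it. The added methyl on the saturated chain carbon gives a 1.3-fold higher number from compound 3 to compound 4 (0.10 log units; within the scatter), and exchanging the 2-cyanophenyl for 4-isopropylphenyl on the aromatic nitrogen gives a 1.3-fold higher number from compound 2 to compound 4 (0.10 log units; within the scatter), both also within the scatter, so the ethyl, isopropyl and 2-cyanophenyl compounds cannot be told apart here and the small step seen with ethyl is not shown to extend to the larger alkyl group. Nothing available accounts for these numbers or for how isopropyl and ethyl compare with methoxy.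

The compounds shown leave open how a tert-butyl group, a longer chain such as butyl, an amine or a carboxylic acid would read at this aromatic carbon. They also leave open whether any replacement of methoxy there can give a step larger than the modest ones seen so far.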